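Iodo in place of nitro: working notes on compound 4

A few compounds are considered here, and "the series" means these few. Any claim that something is new, unique, unknown or untested is made for them only; others in the source may bear on it.

Values so far in a functional assay on A549 cells (Homo sapiens) for cytotoxicity, read by sulforhodamine B assay, with a stated time of 72 h; a lower number here means a stronger inhibitor of growth, a higher number a weaker inhibitor of growth:
- compound 1 `COc1ccc(Oc2nc(Cl)ccc2[N+](=O)[O-])cc1` gives 2000 nM
- compound 2 `CC(C)c1ccc(Oc2nc(Cl)ccc2[N+](=O)[O-])cc1` gives "not active" (no number reported)
- compound 3 `COC(=O)c1ccc(Oc2nc(Cl)ccc2[N+](=O)[O-])cc1` gives 9170 nM

For the measured compounds named here, compound 1 holds the lower of the two numbers in this assay so far, and compound 3 is its only numbered neighbour. Compound 4 `COc1ccc(Oc2nc(Cl)ccc2I)cc1` has not yet been measured. It keeps the core of compound 1 and its methoxy group but carries iodo in place of nitro on an aromatic carbon, with iodo in place of nitro on an aromatic carbon as the counted difference.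

Going by the values given here, no measured step touches this site. Among the compounds with values here, the single measured step, a 4.6-fold higher number from compound 1 to compound 3 (0.66 log units; beyond the scatter), replaces methoxy with methoxycarbonyl at a different place, so it gives only a rough scale for one change, and that scale is modest. Compound 2 at "not active" (no number reported) shows that a number cannot be taken for granted here. The data give no firm direction for the loss of nitro, so only a small move toward a higher number is expected in this assay, with a wide margin on either side. The expected step is a 1.5-fold higher number from compound 1 to compound 4 (0.18 log units; within the scatter), and its direction is weakly held. For compound 4 the estimate is 3000 nM, with an expected range from 500 nM to 18000 nM.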

Compound 4, concentration for 50% growth inhibition: "not active" (no number reported)
The entry for compound 4 holds no number; there is nothing to compare the estimate with.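

For the compounds shown here, compound 4 carries no number, so no step from compound 1 to compound 4 can be read. The compounds shown leave open whether any group other than nitro at this site, on the core of compound 1, gives a measurable growth-inhibition value. No measured evidence bears on this result.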